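Moving the trifluoromethyl group around the aryl ring

The source may report more compounds than this note shows. Statements on the series, on what has been measured and on what is new or still open speak of the compounds shown alone.

The compounds measured so far:
compound 1 `C[C@H](c1ccc(C(=O)NCCC(=O)O)cc1)N1C(=O)C(c2ccc(F)cc2)=N[C@]12CC[C@@H](C(C)(C)C)CC2`, 430 nM
compound 2 `CC(C)(C)[C@H]1CC[C@]2(CC1)N=C(c1cccc(C(F)(F)F)c1)C(=O)N2Cc1ccc(C(=O)NCCC(=O)O)cc1`, 510 nM
compound 3 `C[C@H](c1ccc(C(=O)NCCC(=O)O)cc1)N1C(=O)C(c2cccc(Cl)c2)=N[C@]12CC[C@@H](C(C)(C)C)CC2`, 480 nM

In a functional assay on CHO cells for antagonist activity at Glucagon receptor (Homo sapiens), read by cAMP accumulation, with stated times of 30 min and 45 min (a lower number here means a stronger inhibitor, a higher number a weaker inhibitor), compound 2 gives the highest of the three numbers, yet both compound 3 and compound 1 lie within the scatter of it, so no order among them can be claimed. Compound 4 `CC(C)(C)[C@H]1CC[C@]2(CC1)N=C(c1ccc(C(F)(F)F)cc1)C(=O)N2Cc1ccc(C(=O)NCCC(=O)O)cc1` differs from compound 2 only in this way: 4-(trifluoromethyl)phenyl in place of 3-(trifluoromethyl)phenyl on a carbon with a double bond to nitrogen. Within the data shown here, only one measured step changes the group on that carbon: a 1.1-fold higher number from compound 1 to compound 3 (0.05 log units; within the scatter). That swap of one aryl group for another left the number within the scatter, so no step beyond the scatter is expected here either. Compound 4 is therefore estimated at 510 nM, within 250 nM to 1050 nM, a change of no change at the digits printed from compound 2 to compound 4 (within the scatter).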

Compound 4, half-maximal inhibitory concentration: 800 nM
Compound 4: middle estimate off by 1.6-fold (0.20 log units), on the low side; low and high end bracket the measured number.
By their numbers in this assay, from the lowest: compounds 1, 3, 2 and 4 (each within the scatter of the next).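

Swapping 3-(trifluoromethyl)phenyl for 4-(trifluoromethyl)phenyl keeps the same atoms and gives a 1.6-fold higher number from compound 2 to compound 4 (0.20 log units; within the scatter) in this assay and thus stays inside the scatter. So at this position, moving one group around the aryl ring, and not only exchanging one aryl group for another, has yet to produce a clear step. Nothing measured here speaks to why the step has this size. Still open, as far as these compounds go, is whether 2-(trifluoromethyl)phenyl, or a nitrile or methoxy group on that aryl ring, would give a number beyond the scatter.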